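This account rests on a few compounds, and the source may have more. Where it says the series, first, only, none or still open, it means among the compounds named here.

Measured so far:
compound 1 `COc1ccc2[nH]cc(/C=C(\C#N)C(=O)c3c[nH]c4ccccc34)c2c1` gives 25100 nM
compound 2 `N#C/C(=C\c1c[nH]c2ccccc12)C(=O)c1c[nH]c2ccccc12` gives 36800 nM

In a functional assay on MIA PaCa-2 cells (Homo sapiens) for cytotoxicity, read by WST assay, with a stated time of 48 h (on this read-out higher numbers stand for weaker inhibition and lower numbers for stronger inhibition), compound 2 stands at 36800 nM and lies within the scatter of compound 1 at 25100 nM. Compound 3 `COc1ccc(-c2[nH]c3ccccc3c2/C=C(\C#N)C(=O)c2c[nH]c3ccccc23)cc1` differs from compound 2 by 4-methoxyphenyl in place of hydrogen on an aromatic carbon, which is 4-methoxyphenyl in place of hydrogen on an aromatic carbon. Among the measured compounds shown here, the only measured step, a 1.5-fold higher number from compound 1 to compound 2 (0.17 log units; within the scatter), concerns a different place and a far smaller group, so it gives little guidance here. The data fix no direction, and a modest move to a lower number is only a tentative expectation. The estimated change is a 2.3-fold lower number from compound 2 to compound 3 (0.36 log units; beyond the scatter) and may prove to lie within the scatter. For compound 3 the estimated value is 16000 nM, with an expected range of 4000 nM to 55000 nM.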

Compound 3, half-maximal inhibitory concentration: > 50000 nM
Compound 3: a limit, no number (the forecaster's own chance of this, stated with the estimate: 10%); middle value at least 3.1-fold (0.49 log units) away from the limit.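

In this assay compound 3 gives > 50000 nM, which is a limit and not a number. The step is an at least 1.3-fold higher number from compound 2 to compound 3 (0.13 log units; that floor lies within the scatter), so only a floor is known, yet 4-methoxyphenyl in place of hydrogen on this aromatic carbon next to the ring nitrogen brings no move to a lower number. This is the only change shown at this position, and the series now holds one reading without a true number: the limit of > 50000 nM in this assay, at which 1 of the 3 values shown sits.

As far as these compounds go, the true size of the step stays open. Also open, from the compounds shown here alone, is how a smaller group at this place, such as methyl, an amine or unsubstituted phenyl, would read.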